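Swapping the amide aryl group in a phosphodiesterase series

A few compounds are considered here, and "the series" means these few. Any claim that something is new, unique, unknown or untested is made for them only; others in the source may bear on it.

Measured compounds:
compound 1 `COc1ccc(C(=O)Nc2ccccc2Cl)cc1OC(=O)C1CCCC1`: > 1000000 nM
compound 2 `COc1ccc(C(=O)Nc2ccccn2)cc1OC1CCCC1`: 1000 nM

In an assay on isolated protein for inhibition of phosphodiesterase 4A (Sus scrofa) (a higher number here means a weaker inhibitor, a lower number a stronger inhibitor), compound 1 reaches only a limit of the assay, > 1000000 nM, which is the limit of > 1000000 nM in this assay, at which 1 of the 2 values shown sits. Among the measured compounds shown here, compound 2 gives 1000 nM in this assay, the only true number among the two values. Compound 3 `COc1ccc(C(=O)Nc2c(C)nsc2C#N)cc1OC1CCCC1` differs from compound 2 in one place: 5-cyano-3-methyl-1,2-thiazol-4-yl in place of pyridin-2-yl on an amide-type nitrogen. For the measured compounds named here, no measured step covers this change, so the expected step of a 1.3-fold lower number from compound 2 to compound 3 (0.10 log units; within the scatter) is small, not clearly beyond the scatter in either direction. Compound 3 is therefore estimated at 800 nM in this assay, with a range from 150 nM to 5000 nM.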

Compound 3, half-maximal inhibitory concentration: 200 nM
Estimate against measurement, compound 3: 4.0-fold (0.60 log units) above, and the stated range covers the measured number.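

In this assay, placing 5-cyano-3-methyl-1,2-thiazol-4-yl instead of pyridin-2-yl on the amide-type nitrogen gives a 5.0-fold lower number from compound 2 to compound 3 (0.70 log units; beyond the scatter). This position therefore accepts a five-membered aromatic ring with a sulfur atom in place of a six-membered one, and the inhibition is stronger with it. Nothing measured here accounts for the difference. From the compounds shown here alone, whether it comes from the ring itself, the nitrile or the methyl group remains open, since these three parts enter together. Also open, going by these compounds, is how a plain phenyl ring or a carboxylic acid would read on this nitrogen.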